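Methylating the Chloro Compound at Its Ring Nitrogen

The compounds below may be only part of what the source reports. "The series", "measured", "known", "first", "only" and "open" are said of these compounds alone.

In a functional assay on K562 cells (Homo sapiens) for antiproliferative activity, read by MTT assay, with a stated time of 48 h (on this read-out higher numbers stand for weaker inhibition of growth and lower numbers for stronger inhibition of growth), compound 1 (`COc1ccc(N(C)c2ncnc3[nH]cnc23)cc1`) gives > 100000 nM, which is a limit of the assay and not a number. Compound 2 (`COc1ccc(N(C)c2ncnc3c2ncn3C)cc1`) gives > 100000 nM, again a limit. Compound 3 (`COc1ccc(N(C)c2nc(Cl)nc3[nH]cnc23)cc1`) gives > 100000 nM, also only a limit. All the measured compounds therefore sit at the limit of > 100000 nM in this assay, at which 3 of the 3 values shown sit.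

Compound 4 (`COc1ccc(N(C)c2nc(Cl)nc3c2ncn3C)cc1`) differs from compound 3 by one change: methyl in place of hydrogen on an aromatic nitrogen, a methyl in place of hydrogen on an aromatic nitrogen. The same replacement was made once before, giving a step that the two limits leave unreadable from compound 1 to compound 2. The chloro in place of hydrogen gave a step that the two limits leave unreadable from compound 1 to compound 3. Within the data shown here, neither step has a readable size, so the data offer no measured precedent for a gain or a loss.

The most likely outcome is that compound 4 stays close to the limit, with some chance of a readable value on the side of stronger inhibition. The expected move is an at least 3.3-fold lower number from compound 3 to compound 4 (0.52 log units; beyond the scatter). For compound 4 the estimated value is 30000 nM, with an expected range from 1000 nM to 100000 nM.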

Compound 4, concentration for 50% growth inhibition: 2300 nM
Compound 4: the middle estimate sits 13-fold (1.12 log units) above what was measured; the range from low to high includes it.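

In this assay, the methyl on the aromatic nitrogen now has a readable effect when the chloro is present, with an at least 43-fold lower number from compound 3 to compound 4 (1.63 log units; beyond the scatter). Among these compounds, with that methyl present, the chloro also has a readable effect, with an at least 43-fold lower number from compound 2 to compound 4 (1.63 log units; beyond the scatter), whereas the earlier steps from compound 1 cannot be read. Only the two changes together, in compound 4, give a value clear of the limit, while compound 2 and compound 3, each carrying one of them, stay with compound 1 at that limit: the limit of > 100000 nM in this assay, at which 3 of the 4 values shown sit.

From the compounds shown here alone, both steps start from a limit, so their full size remains open. The compounds shown also leave open whether an ethyl on the same ring nitrogen, or an amine in place of the chloro, would keep this level of growth inhibition.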